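A few compounds are considered here, and "the series" means these few. Any claim that something is new, unique, unknown or untested is made for them only; others in the source may bear on it.

In a physicochemical assay for solubility, at pH 6.5 (on this read-out higher numbers stand for higher solubility and lower numbers for lower solubility), compound 1 `O=C(Nc1ccccc1)c1cc2cc(Cl)cc(Br)c2oc1=O` gives 0.59 ug/mL, while compound 2 `O=C(Nc1ccc(O)cc1)c1cc2cc(Cl)cc(Br)c2oc1=O` gives 1.5 ug/mL. For the measured compounds named here, compound 2 thus holds the higher of the two numbers measured so far. Going by the values given here, the only measured step is a 2.5-fold higher number from compound 1 to compound 2 (0.41 log units; beyond the scatter), a modest one that comes with hydroxy in place of hydrogen on an aromatic carbon.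

Compound 3 `O=C(Nc1ccccc1O)c1cc2cc(Cl)cc(Br)c2oc1=O` has the same atoms as compound 2, joined differently: 2-hydroxyphenyl in place of 4-hydroxyphenyl on an amide-type nitrogen. The hydroxy group is kept, and 2-hydroxyphenyl stands in place of 4-hydroxyphenyl on an amide-type nitrogen. The measured step therefore bears on this change only indirectly. Among the compounds with values here, it shows what happened when a hydroxy group was added, but no measured pair compares one hydroxyphenyl with another. With so little evidence, no step beyond the scatter is expected in this assay, and any drift is expected to be slightly downward. The expected change is a 1.5-fold lower number from compound 2 to compound 3 (0.18 log units; within the scatter). For compound 3, the estimated value is 1 ug/mL, with an expected range of 0.4 ug/mL to 2.5 ug/mL.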

Compound 3, solubility: 0.71 ug/mL
Compound 3: middle estimate off by 1.4-fold (0.15 log units), on the high side; the range from low to high includes it.
By their numbers in this assay, from the lowest: compounds 1 and 3 (each within the scatter of the next); then compound 2.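

In this assay, the result shows that where the hydroxy group sits on the phenyl ring matters, and not only whether it is present: 2-hydroxyphenyl in place of 4-hydroxyphenyl on the amide-type nitrogen gives a 2.1-fold lower number from compound 2 to compound 3 (0.32 log units; beyond the scatter), a modest step. Read against the plain phenyl compound, adding the hydroxy group in the 2-hydroxyphenyl arrangement gives a 1.2-fold higher number from compound 1 to compound 3 (0.08 log units; within the scatter), so among the compounds shown, the earlier rise from adding a hydroxy group appears only with 4-hydroxyphenyl and does not carry over to 2-hydroxyphenyl. Nothing given here accounts for the difference between the two hydroxyphenyl groups.

The compounds shown leave open whether this dependence on placement is particular to the hydroxy group, or whether an amine, a methoxy group or a carboxylic acid in its place on the phenyl ring would follow the same order on this read-out. All three compounds also share one core, so whether the step between 4-hydroxyphenyl and 2-hydroxyphenyl keeps its size with the chlorine or the bromine replaced by another group remains an open question.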